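The compounds below may be only part of what the source reports. "The series", "measured", "known", "first", "only" and "open" are said of these compounds alone.

Measured so far:
- compound 1 `ClCc1cccc(Cn2cnc3c(Cl)nc(Cl)nc32)c1`: 2040 nM
- compound 2 `Nc1nc(Cl)c2ncn(Cc3ccccc3CCl)c2n1`: 6030 nM

In a functional assay on MCF7 cells (Homo sapiens) for cytotoxicity, read by sulforhodamine B assay, with a stated time of 48 h (a higher number here means a weaker inhibitor of growth, a lower number a stronger inhibitor of growth), compound 1 gives 2040 nM. In this assay compound 2 gives 6030 nM, the highest of the two numbers; compound 1 stands nearest, and the gap between them lies beyond the scatter. Going by the values given here, no pair among the measured compounds differs in only one place, so no single step has been measured directly.

Compound 3 `ClCc1ccccc1Cn1cnc2c(Cl)ncnc21` is not yet measured. Relative to compound 2 the change is hydrogen in place of amino on an aromatic carbon. Among the compounds with values here, no step of this kind has been measured, so the expectation rests on the change alone. In this assay the step is expected to be a 1.5-fold lower number from compound 2 to compound 3 (0.18 log units; within the scatter), a modest move toward a lower number. For compound 3 the estimate in this assay is 4000 nM, with a range from 1500 nM to 12000 nM.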

Compound 3, concentration for 50% growth inhibition: 11000 nM
The estimate for compound 3 lay 2.8-fold (0.44 log units) below the measured number, and the stated range covers the measured number.
By their numbers in this assay, from the lowest: compound 1; then compounds 2 and 3 (each within the scatter of the next).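

Going by these compounds alone, this is the first measured step at the aromatic carbon between two ring nitrogen atoms. In this assay, hydrogen in place of amino gives a 1.8-fold higher number from compound 2 to compound 3 (0.26 log units; within the scatter), so this single pair does not show that the amino group is needed for growth inhibition in MCF7 cells under these conditions. Nothing available bears on what lies behind this result.

Within the data shown here, only one substituent swap has been read at this carbon, and on only one placement of the chloromethyl group, so it remains open whether the same step would hold with the chloromethyl group placed as in compound 1. As far as these compounds go, it also remains open how a methylamino, dimethylamino or methoxy group at this carbon would compare with amino and hydrogen.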